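Dimethylpiperazine in place of piperazine on two cores

The source may hold more compounds than are shown below. What is called first, only, known or untested is meant among the compounds shown, and "the series" means these compounds.

Compound 1 `O=C(O)c1cn(C2CC2)c2c(C(F)(F)F)c(N3CCNCC3)c(F)cc2c1=O` and compound 2 `O=C(O)c1cn(C2CC2)c2nc(N3CCNCC3)c(F)cc2c1=O` carry the same piperazin-1-yl group on different cores; the difference between the two cores is not broken down here. In a functional assay on V79 cells (Cricetulus griseus) for cytotoxicity, read by colony formation (a higher number here means a weaker inhibitor, a lower number a stronger inhibitor), compound 1 gives 1650 ug/mL. In this assay, among the compounds with values here, compound 2 gives 120 ug/mL, the lowest of the two numbers read so far, with compound 1 the nearest neighbour and a gap that lies beyond the scatter.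

Compound 3 `CC1CN(c2c(F)cc3c(=O)c(C(=O)O)cn(C4CC4)c3c2C(F)(F)F)CC(C)N1` differs from compound 1 by 3,5-dimethylpiperazin-1-yl in place of piperazin-1-yl on an aromatic carbon. For compound 3 this assay reports only a limit, > 500 ug/mL, so the limit of > 500 ug/mL in this assay, at which 1 of the 3 values shown sits, applies and the step that the limit leaves unreadable from compound 1 to compound 3 cannot be read.

Compound 4 `CC1CN(c2nc3c(cc2F)c(=O)c(C(=O)O)cn3C2CC2)CC(C)N1` differs from compound 2 by 3,5-dimethylpiperazin-1-yl in place of piperazin-1-yl on an aromatic carbon. This is the same kind of change as from compound 1 to compound 3, not the same: in compound 4 the group sits on a ring with 1 nitrogen, next to the ring nitrogen, whereas in compound 3 it sits on a ring of carbon only, ortho to a trifluoromethyl group.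

Within the data shown here, the one measured instance of the change is hidden behind a limit. The expectation for compound 4 therefore rests only on the value of compound 2, 120 ug/mL, and is set close to it: the step of a 1.7-fold higher number from compound 2 to compound 4 (0.22 log units; within the scatter) is expected to stay within the scatter. Compound 4 is therefore estimated at 200 ug/mL in this assay, with a range from 60 ug/mL to 700 ug/mL.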

Compound 4, half-maximal inhibitory concentration: 250 ug/mL
Beside the measured number, compound 4's estimate is 1.3-fold (0.10 log units) below it; the range from low to high includes it.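

In this assay, 3,5-dimethylpiperazin-1-yl in place of piperazin-1-yl, next to the ring nitrogen on the core of compound 2, gives a 2.1-fold higher number from compound 2 to compound 4 (0.32 log units; beyond the scatter), a modest step and the only readable instance of this change among the compounds shown. For compound 3 only a limit is reported, so the step to it from compound 1 cannot be read and the second core adds no size for comparison: the limit of > 500 ug/mL in this assay, at which 1 of the 4 values shown sits. The change therefore has one measured size on one core, which shows that it can raise the number in this assay but not that the size or even the direction carries over to the core of compound 1, and a single pair sets no pattern for the series.

A numerical value for compound 3 would be needed before the two cores could be compared. Also open, from the compounds shown here alone, is how a 3-methylpiperazin-1-yl group, with one methyl rather than two, or a morpholin-4-yl group, with ring oxygen in place of the ring amine, would read at the same place on either core.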